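Replacing the acetyl(methyl)amino group of compound 2

The source may hold more compounds than are shown below. What is called first, only, known or untested is meant among the compounds shown, and "the series" means these compounds.

Compound 1 `CC(=O)NCC#CCn1cncc1C` gives 66 mg/kg
Compound 2 `CC(=O)N(C)CC#CCn1cncc1C` gives > 100 mg/kg

Both readings come from a functional assay on the whole organism for antagonist activity, with Mus musculus as the target (a lower number here means that less compound is needed, a higher number that more compound is needed for the effect), and they do not carry equal weight. For compound 2 the reading > 100 mg/kg is a limit of the assay and not a number.

Compound 3 `COC(=O)NCC#CCn1cncc1C` differs from compound 2 in one place (methoxycarbonyl)amino in place of acetyl(methyl)amino on a saturated chain carbon bound to a triple-bonded carbon with (methoxycarbonyl)amino in place of acetyl(methyl)amino on a saturated chain carbon bound to a triple-bonded carbon.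

Going by the values given here, one measured step bears on this change. It is an at least 1.5-fold higher number from compound 1 to compound 2 (0.18 log units; that floor lies within the scatter) and it comes from methyl in place of hydrogen on an amide-type nitrogen. Among the compounds with values here, the entering group again has a hydrogen-bond donor, so that step read backwards is the nearest guide, although no measured step covers the swap from acetyl to methoxycarbonyl. Within the data shown here, with compound 1 at 66 mg/kg as the only true number available, a modest move towards a lower dose is expected. The expected step is an at least 1.4-fold lower number from compound 2 to compound 3 (0.15 log units; that floor lies within the scatter) as an estimate. For compound 3 the estimated value is 70 mg/kg with an expected range from 30 mg/kg to 160 mg/kg as its likely span.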

Compound 3, dose for half-maximal effect: 80 mg/kg
For compound 3 the middle estimate is 1.1-fold (0.06 log units) below the measured one, within the range that was stated.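

In this assay, methoxy can stand in place of methyl on the carbonyl carbon while the amide hydrogen stays: the result is a 1.2-fold higher number from compound 1 to compound 3 (0.08 log units; within the scatter), so this change leaves the two compounds indistinguishable in this test. The comparison with the methylated nitrogen is far less firm, since an at least 1.2-fold lower number from compound 2 to compound 3 (0.09 log units; that floor lies within the scatter) gives only a floor, and that floor does not clear the usual scatter, so a real difference is neither shown nor ruled out. That step has no upper end because compound 2 carries a limit and not a number: the limit of > 100 mg/kg in this assay, at which 1 of the 3 values shown sits.

From the compounds shown here alone, it remains open whether methyl on the nitrogen of the (methoxycarbonyl)amino group would also give only a limit, which would test whether the hydrogen on that nitrogen matters with either carbonyl group. Also unresolved is how this assay would respond to a urea, a free amine or a longer ethoxycarbonyl group on a saturated chain carbon bound to a triple-bonded carbon, since the shared core has so far carried only these closely related groups.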